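The compounds below may be only part of what the source reports. "The series", "measured", "known", "first", "only" and "open" are said of these compounds alone.

Measured so far in a functional assay on Jurkat cells (Homo sapiens) for activation, with a stated time of 24 h; on this read-out lower numbers stand for an effect already at smaller amounts and higher numbers for an effect only at larger amounts of compound:

- compound 1 `Oc1ccccc1CNc1ccc(-c2ccccc2)cc1`: 1820 nM
- compound 2 `Oc1ccccc1CNc1ccc(-c2ccc(F)cc2)cc1`: 3860 nM
- compound 3 `Oc1ccccc1CNc1ccc(-c2ccccc2)nc1`: 840 nM

Compound 3 carries the lowest number of the three, and its steps to compound 1 and to compound 2 both lie beyond the scatter. The difference between the core of compound 3 and the core of compound 1 is not broken down here.

One change has been made once within the measured set. Going from compound 1 to compound 2 the change is fluoro in place of hydrogen on an aromatic carbon, and in this assay it gave a 2.1-fold higher number from compound 1 to compound 2 (0.33 log units; beyond the scatter).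

Compound 4 `Oc1ccccc1CNc1ccc(-c2ccc(F)cc2)nc1` has not yet been measured in this assay. It differs from compound 3 by fluoro in place of hydrogen on an aromatic carbon. The place is described in the same words for both pairs, so this is the same change, now made on the core of compound 3.

Going by the values given here, with only that single earlier instance to rest on, compound 4 is expected to shift from compound 3 by a 2.0-fold higher number from compound 3 to compound 4 (0.31 log units; beyond the scatter), a step of about the size seen as a 2.1-fold higher number from compound 1 to compound 2 (0.33 log units; beyond the scatter). Whether the change behaves alike on the two cores is not known from these data, so the range is kept wide.

Compound 4 is estimated at 1700 nM in this assay, with the likely span running from 700 nM to 4500 nM.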

Compound 4, half-maximal effective concentration: 2590 nM
The estimate for compound 4 lay 1.5-fold (0.18 log units) below the measured number; measured number inside the range.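

In this assay, phenyl to 4-fluorophenyl on the core of compound 3 gives a 3.1-fold higher number from compound 3 to compound 4 (0.49 log units; beyond the scatter), and this step does not differ from the earlier one: the same change on two cores in this assay, a 2.1-fold higher number (0.33 log units; beyond the scatter) from compound 1 to compound 2 and a 3.1-fold higher number (0.49 log units; beyond the scatter) from compound 3 to compound 4, 1.5-fold (0.16 log units) apart, within the scatter of two such steps. Within this series, the change therefore carries from one core to the other, with the number moving the same way on both and the sizes of the two steps not told apart. Going by these compounds alone, this rests on only two pairs, both with fluoro at the same place, so it does not show that the change would carry to any further core, and the data give no reason for the shift.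

The compounds shown leave open how a chloro, methoxy or trifluoromethyl group at that same place would compare with fluoro on either core. Also open, on these data alone, is whether the step holds when the hydroxyl group on the other ring gives way to a methoxy group or an amine.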